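This account rests on a few compounds, and the source may have more. Where it says the series, first, only, none or still open, it means among the compounds named here.

- Compound 1 `CCc1ccc(SCc2ccc(/C=C/C(=O)Nc3ccccc3N)cc2)cc1` gives 68.6%
- Compound 2 `CCc1ccc(SCc2ccc(C(=O)Nc3ccccc3N)cc2)cc1` gives 91.4%
- Compound 3 `CC(C)(C)c1ccc(SCc2ccc(C(=O)Nc3ccccc3N)cc2)cc1` gives 67%

In a functional assay on A549 cells (Homo sapiens) for inhibition, read by CCK-8 assay, with a stated time of 72 h, tested at 8 uM (on this read-out lower numbers stand for less inhibition of growth and higher numbers for more inhibition of growth at the one concentration tested), compound 1 gives 68.6% and so lies within the usual scatter of compound 3 at 67%, while compound 2 stands clearly higher at 91.4%. The unmeasured compound 4 `CC(C)(C)c1ccc(SCc2ccc(/C=C/C(=O)Nc3ccccc3N)cc2)cc1` has tert-butyl in place of ethyl on an aromatic carbon, para to a large group (tert-butyl in place of ethyl on an aromatic carbon). One measured step makes the same swap on a different core: a number 24.4 percentage points lower from compound 2 to compound 3 (beyond the scatter). That is a single example, and compound 2 started higher at 91.4%, so a fall in the same direction but of somewhat smaller size is expected here. The estimated change is a number 17.6 percentage points lower from compound 1 to compound 4 (beyond the scatter). For compound 4 the expected value is 51%, with an estimated range of 33% to 69%.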

Compound 4, percent growth inhibition at one concentration: 79.8%
Compound 4: the middle estimate sits 28.8 percentage points below what was measured; measured number above the stated range.
By their numbers in this assay, from the lowest: compounds 3 and 1 (each within the scatter of the next); then compound 4; then compound 2.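

In this assay the swap of ethyl for tert-butyl on this aromatic carbon gives a number 11.2 percentage points higher from compound 1 to compound 4 (beyond the scatter) and so runs opposite to the earlier step. The position therefore has no single effect of this change that carries over from one core to another, and the outcome for this swap differs with the core that bears it: the same change on two cores in this assay, a number 24.4 percentage points lower (beyond the scatter) from compound 2 to compound 3 and a number 11.2 percentage points higher (beyond the scatter) from compound 1 to compound 4, 35.6 percentage points apart, beyond the scatter of two such steps.

Among the compounds shown here, only two cores carry this swap, so the pattern rests on a single pair of steps. From the compounds shown here alone, how an amine or a carboxylic acid in the same place would behave on either core remains open.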